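The source may report more compounds than this note shows. Statements on the series, on what has been measured and on what is new or still open speak of the compounds shown alone.

Among the measured compounds shown here, in a functional assay on T47D cells (Homo sapiens) for inhibition, read by CCK-8 assay, with a stated time of 72 h, tested at 1 uM (on this read-out lower numbers stand for less inhibition of growth and higher numbers for more inhibition of growth at the one concentration tested), compound 1 `COc1ccc(NC(=O)C2(C(=O)Nc3ccc(Nc4ncc5cc(C(=O)N(C)C)n(C6CCCC6)c5n4)cc3)CC2)cc1` gives 76.4% and compound 2 `CN(C)C(=O)c1cc2cnc(Nc3ccc(NC(=O)C4(C(=O)Nc5ccc(Br)cc5)CC4)cc3)nc2n1C1CCCC1` gives 21.1%, the lower of the two numbers available so far. The next structure is compound 3 `CN(C)C(=O)c1cc2cnc(Nc3ccc(NC(=O)C4(C(=O)Nc5ccc(Cl)c(C(F)(F)F)c5)CC4)cc3)nc2n1C1CCCC1`, which differs from compound 2 as follows: 4-chloro-3-(trifluoromethyl)phenyl in place of 4-bromophenyl on an amide-type nitrogen. In words, this is 4-chloro-3-(trifluoromethyl)phenyl in place of 4-bromophenyl on an amide-type nitrogen.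

For the measured compounds named here, only one measured step bears on this change: a number 55.3 percentage points lower from compound 1 to compound 2 (beyond the scatter), a large step that came from bromo in place of methoxy on an aromatic carbon. It shows that a change on this aromatic group can shift the read-out strongly, but it gives no direct guide to direction here. Going by the values given here, no measured compound carries chloro or trifluoromethyl. Compound 2 at 21.1% leaves more room upward than downward, so a modest rise is expected, with wide uncertainty. The estimated step in this assay is a number 13.9 percentage points higher from compound 2 to compound 3 (beyond the scatter), smaller in size than the one measured. In this assay, compound 3 is estimated at 35%, with an expected range of 12% to 65%.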

Compound 3, percent growth inhibition at one concentration: 6.9%
Beside the measured number, compound 3's estimate is 28.1 percentage points above it; the whole stated range lies above it.
By their numbers in this assay, from the lowest: compound 3; then compound 2; then compound 1.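

In this assay the amide-nitrogen aryl position responds to a change that keeps an aromatic ring and swaps only its substituents: the step is a number 14.2 percentage points lower from compound 2 to compound 3 (beyond the scatter), so the read-out still falls when the starting point is already low. Set against the methoxy-bearing compound, the drop is a number 69.5 percentage points lower from compound 1 to compound 3 (beyond the scatter), which makes 4-chloro-3-(trifluoromethyl)phenyl the lowest of the three aryl groups shown and leaves 4-methoxyphenyl clearly the highest, with each step between the three beyond the scatter. No measurement at hand accounts for this order.

Three aryl groups cannot separate the effect of losing the methoxy group from the effect of the groups that replace it, nor the contribution of chloro from that of trifluoromethyl within the entering group. An unsubstituted phenyl, a 4-ethoxyphenyl or a 4-(dimethylamino)phenyl on the same nitrogen would show whether the high read-out is particular to methoxy, and a 4-chlorophenyl or 3-(trifluoromethyl)phenyl would divide the last step between its two substituents.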